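This account rests on a few compounds, and the source may have more. Where it says the series, first, only, none or still open, it means among the compounds named here.

Compound 1 `C[C@@H](CNc1ccc(OC(F)(F)F)cc1)NC(=O)[C@H](CCC(C)(C)C)CC(=O)N1CCOCC1` gives 70 nM in an assay on isolated protein for inhibition of cathepsin S (Homo sapiens); a higher number here means a weaker inhibitor, a lower number a stronger inhibitor. Compound 2 `C[C@@H](CNc1ccc(OC(F)(F)F)cc1)NC(=O)[C@@H](CC(=O)N1CCOCC1)CC1CCCC1` gives 31 nM. Compound 3 `C[C@@H](CNc1ccc(OC(F)(F)F)cc1)NC(=O)[C@H](CCC1CCCCC1)CC(=O)N1CCOCC1` gives 95 nM.

Compound 2 has the lowest of the three numbers, set apart from the others by a 2.3-fold lower number from compound 1 to compound 2 (0.35 log units; beyond the scatter) and by a 3.1-fold higher number from compound 2 to compound 3 (0.49 log units; beyond the scatter). Compound 4 `CC(C)[C@@H](CNc1ccc(OC(F)(F)F)cc1)NC(=O)[C@@H](CC(=O)N1CCOCC1)CC1CCCC1` differs from compound 2 at another place: isopropyl in place of methyl on a saturated chain carbon bound to an amide-type nitrogen and a saturated chain carbon. Among the compounds with values here, none of the measured steps concerns this position; a 2.3-fold lower number from compound 1 to compound 2 (0.35 log units; beyond the scatter), a 1.4-fold higher number from compound 1 to compound 3 (0.13 log units; within the scatter) and a 3.1-fold higher number from compound 2 to compound 3 (0.49 log units; beyond the scatter) all exchange the group on a different saturated chain carbon, and each is modest or within the scatter. Without direct guidance, compound 4 is expected to show only a small step, a 1.0-fold lower number from compound 2 to compound 4 (0.01 log units; within the scatter), within the scatter. Compound 4 is therefore estimated at 30 nM, between 12 nM and 75 nM.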

Compound 4, inhibition constant: 38 nM
Beside the measured number, compound 4's estimate is 1.3-fold (0.10 log units) below it, within the range that was stated.
By their numbers in this assay, from the lowest: compounds 2, 4, 1 and 3 (each within the scatter of the next, the first and the last beyond it).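

Within the data shown here, until now, every step changed the group on a different saturated chain carbon, so this is the first reading at the saturated chain carbon bound to an amide-type nitrogen and a saturated chain carbon. In this assay isopropyl in place of methyl there gives a 1.2-fold higher number from compound 2 to compound 4 (0.09 log units; within the scatter) and so no change beyond the scatter. No measurement at hand explains this small step.

As far as these compounds go, whether an amine or a carboxylic acid at this place would also leave the number unmoved remains open. So does whether isopropyl behaves the same alongside the neopentyl of compound 1 or the cyclohexylmethyl of compound 3.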